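Aryl swap on the shared core: expected maximal response

A few compounds are considered here, and "the series" means these few. Any claim that something is new, unique, unknown or untested is made for them only; others in the source may bear on it.

Measured compounds:
compound 1 `NS(=O)(=O)c1ccc(-c2nc(C(c3ccc(F)cc3)c3ccc(F)cc3)sc2CC(=O)O)cc1` gives 80% in an in vitro functional assay on HEK285-7 cells for antagonist activity at prostaglandin D2 receptor 2 (Homo sapiens), read by BRET and beta-arrestin recruitment; a higher number here means a larger maximal response, a lower number a smaller maximal response
compound 2 `O=C(O)Cc1sc(C(c2ccc(F)cc2)c2ccc(F)cc2)nc1-c1ccc(Cl)cc1` gives 80% in this assay
compound 3 `O=C(O)Cc1sc(C(c2ccccc2)c2ccc(F)cc2)nc1-c1ccc(Cl)cc1` gives 80% in this assay

Compound 2 stands level with compounds 1 and 3 in this assay; none of the three is separated from the others beyond the scatter, so no order among them can be read from these numbers.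

The unmeasured compound 4 `O=C(O)Cc1sc(C(c2ccc(F)cc2)c2ccc(F)cc2)nc1-c1cccc(F)c1` differs from compound 2 in one place: 3-fluorophenyl in place of 4-chlorophenyl on an aromatic carbon.

For the measured compounds named here, two measured steps bear on this change, both touching an aromatic substituent of the shared core. The step of no change at the digits printed from compound 1 to compound 2 (within the scatter) swaps one group on the same aromatic ring that is exchanged here, and the step of no change at the digits printed from compound 2 to compound 3 (within the scatter) alters a fluoro on one of the other aromatic rings. Both left the maximal response unchanged within the scatter. On that basis a step in this assay of no size beyond the scatter is expected from compound 2 to compound 4, that is no change at the digits printed from compound 2 to compound 4 (within the scatter), in no particular direction. Compound 4 is therefore estimated to give 80% in this assay, with an expected range from 66% to 92%.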

Compound 4, largest response reached (reported as efficacy), in percent of the reference or control that the assay uses: 80%
For compound 4 middle estimate and measured number coincide at the digits printed; the measured number falls inside the stated range.
By their numbers in this assay, from the lowest: compounds 1, 2, 3 and 4 (each within the scatter of the next).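

Exchanging 4-chlorophenyl for 3-fluorophenyl on the aromatic carbon next to the ring nitrogen gives no change at the digits printed from compound 2 to compound 4 (within the scatter) in this assay. For the compounds shown here, the earlier compounds carried their substituent only at the 4 position of this phenyl ring, so this is the first sign that both a different halogen and a different place for it on the phenyl ring can be accommodated without leaving the scatter. The wider exchange of 4-sulfamoylphenyl for 3-fluorophenyl gives no change at the digits printed from compound 1 to compound 4 (within the scatter), so all three aryl groups tried at this position read alike in this assay, although they differ in both substituent and substitution place.

No supporting measurement is available to explain why the maximal response stays level across these groups. The compounds shown leave open whether anything at this position would separate from that level, such as a methyl group or a morpholine in place of the whole phenyl ring, or an amine on the phenyl ring.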